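Swapping chloro for fluoro on an inactive core

The source may hold more compounds than are shown below. What is called first, only, known or untested is meant among the compounds shown, and "the series" means these compounds.

Compound 2 `Cc1ccc(S(=O)(=O)Oc2ccc3c(c2C)[C@H](Cn2cc(-c4ccc(Cl)cc4)nn2)[C@@]24CC(=O)[C@@](C)(CC[C@@H]32)C4)cc1` carries a (4-methylphenyl)sulfonyl group on an oxygen of an aromatic ring. In a functional assay on A549 cells (Homo sapiens) for cytotoxicity, read by MTT assay, with a stated time of 4 days (a higher number here means a weaker inhibitor, a lower number a stronger inhibitor), compound 2 gives > 20000 nM, which is a limit of the assay rather than a measured number. Compound 1 `Cc1c(O)ccc2c1[C@H](Cn1cc(-c3ccc(Cl)cc3)nn1)[C@@]13CC(=O)[C@@](C)(CC[C@@H]21)C3` has hydrogen in place of that (4-methylphenyl)sulfonyl and in this assay gives > 20000 nM, again a limit. The comparison between these two is a step that the two limits leave unreadable from compound 1 to compound 2. Compound 3 `C=C1C[C@]23C[C@@]1(O)CC[C@H]2c1cc(Br)c(O)c(C)c1[C@@H]3Cn1cc(-c2ccccn2)nn1`, built on a different core, gives > 20000 nM in this assay, also a limit. Going by the values given here, all three values sit at the limit of > 20000 nM in this assay, at which 3 of the 3 values shown sit, so no measured step has a readable size.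

Compound 4 `Cc1ccc(S(=O)(=O)Oc2ccc3c(c2C)[C@H](Cn2cc(-c4ccc(F)cc4)nn2)[C@@]24CC(=O)[C@@](C)(CC[C@@H]32)C4)cc1` differs from compound 2 by fluoro in place of chloro on an aromatic carbon. Among the compounds with values here, no measured pair touches this exchange of one halogen for another, and the only step among directly related compounds is unreadable. The expectation is accordingly no shift beyond the scatter, with compound 4 most likely also reported as a limit in this assay. Compound 4 is estimated at 30000 nM, with an expected range from 10000 nM to 100000 nM. This estimate corresponds to an expected step that the limit leaves unreadable from compound 2 to compound 4.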

Compound 4, half-maximal inhibitory concentration: > 20000 nM
Compound 4 was reported as a limit (the forecaster's own chance of this, stated with the estimate: 85%); the middle value is on the limit's open side.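

Compound 2 and compound 4 are both reported only as limits, so swapping chloro for fluoro gives no step of readable size: the limit of > 20000 nM in this assay, at which 4 of the 4 values shown sit.

The compounds shown leave open whether either halogen, or any other change shown here, affects the result in this assay; none of them gives a measured number.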